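From 4-methoxyphenyl to furan-3-yl on a shared core

The source may hold more compounds than are shown below. What is called first, only, known or untested is meant among the compounds shown, and "the series" means these compounds.

In a functional assay on HCT-116 cells (Homo sapiens) for antiproliferative activity, read by sulforhodamine B assay, with a stated time of 48 h (on this read-out higher numbers stand for weaker inhibition of growth and lower numbers for stronger inhibition of growth), compound 1 (`COc1cc(C(=O)c2ccc3nc(/C=C/C(=O)NO)ccc3c2)cc(OC)c1OC`) reads 2620 nM and compound 2 (`COc1ccc(Oc2ccc3nc(/C=C/C(=O)NO)ccc3c2)cc1`) reads 1820 nM while compound 3 (`COc1ccc(-c2ccc3nc(/C=C/C(=O)NO)ccc3c2)cc1`) reads 1470 nM on the same scale. Compound 3 thus stands within the scatter of both other compounds, and these numbers set no order among the three.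

Compound 4 (`O=C(/C=C/c1ccc2cc(-c3ccoc3)ccc2n1)NO`) has not yet been measured. It carries furan-3-yl in place of 4-methoxyphenyl on an aromatic carbon and otherwise matches compound 3.

Among the compounds with values here, no measured pair isolates this change, so the evidence is indirect. The expectation rests on compound 3 at 1470 nM and on how closely compound 2 at 1820 nM and compound 1 at 2620 nM sit to it despite their different structures. The expected step of a 1.0-fold higher number from compound 3 to compound 4 (0.01 log units; within the scatter) is estimated to stay within the scatter of this assay with neither direction favoured. Compound 4 is expected to read about 1500 nM with an estimated range of 600 nM to 3500 nM once it is tested.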

Compound 4, concentration for 50% growth inhibition: 1560 nM
Beside the measured number, compound 4's estimate is 1.0-fold (0.02 log units) below it; the measured number falls inside the stated range.
By their numbers in this assay, from the lowest: compounds 3, 4, 2 and 1 (each within the scatter of the next).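

In this assay, the first pair differing in one place gives a 1.1-fold higher number from compound 3 to compound 4 (0.03 log units; within the scatter) on exchanging 4-methoxyphenyl for furan-3-yl at this aromatic carbon. The reading thus stays within the scatter even though the entering group has fewer heavy atoms and a five-membered aromatic ring with one hetero atom instead of a six-membered aromatic ring of carbon only, so this position accepts both groups in this assay. Nothing available here offers an explanation for this result.

Going by these compounds, it remains open whether a group of another kind at this position, such as an amine, a carboxylic acid or a longer chain, would also stay within the scatter. On these data alone, it is also open whether this same exchange would read alike on a different core or in other cells.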